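Pyrimidinyl for pyridinylmethyl on the piperazine of compound 2

The source may report more compounds than this note shows. Statements on the series, on what has been measured and on what is new or still open speak of the compounds shown alone.

Of the compounds shown here, three sharing the same core have been measured in a functional assay on HeLa cells (Homo sapiens) for antiproliferative activity, read by CCK-8 assay, with a stated time of 72 h, tested at 8 uM; on this read-out higher numbers stand for a stronger effect at the one concentration tested and lower numbers for a weaker effect. Compound 1 `CC1CCN(C(=S)SCc2ccc(C(=O)Nc3ccccc3N)cc2)CC1` gives 72.5%, compound 2 `Nc1ccccc1NC(=O)c1ccc(CSC(=S)N2CCN(Cc3ccncc3)CC2)cc1` gives 72.9%, and compound 3 `Nc1ccccc1NC(=O)c1ccc(CSC(=S)N2CCCc3ccccc32)cc1` gives 35.7%. Compound 2 holds the highest number of the three, although its gap to compound 1 lies within the scatter, so the two cannot be ranked against each other; its gap to compound 3 is beyond the scatter. Among the measured compounds shown here, the one step between measured compounds that differ in a single place, a number 36.8 percentage points lower from compound 1 to compound 3 (beyond the scatter), concerns the group on the thiocarbonyl carbon, a place that is not touched in the move now considered.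

Compound 4 `Nc1ccccc1NC(=O)c1ccc(CSC(=S)N2CCN(c3ncccn3)CC2)cc1` differs from compound 2 by pyrimidin-2-yl in place of (pyridin-4-yl)methyl on an amine nitrogen in a ring. For the measured compounds named here, no measured pair shows what changing the group on this ring nitrogen does, so the step from compound 1 to compound 3 cannot be carried over, and the expectation rests on the unchanged remainder of compound 2. The author therefore expects a step from compound 2 to compound 4 in this assay of a number 7.9 percentage points lower from compound 2 to compound 4 (within the scatter), most likely within the scatter or somewhat downward. Compound 4 is estimated at 65%, with a range from 45% to 82%.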

Compound 4, a percentage reported as inhibition, at one concentration (the size of the read-out at that concentration, not a potency): 73.9%
Compound 4: the middle estimate sits 8.9 percentage points below what was measured; measured number inside the range.
By their numbers in this assay, from the lowest: compound 3; then compounds 1, 2 and 4 (each within the scatter of the next).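

The earlier compounds shown here held no pair that changed the group on this ring nitrogen of the six-membered non-aromatic ring; here, in this assay, pyrimidin-2-yl in place of (pyridin-4-yl)methyl gives a number 1 percentage points higher from compound 2 to compound 4 (within the scatter). The exchange replaces a group of 7 heavy atoms, whose six-membered aromatic ring has 1 hetero atom, with a group of 6 heavy atoms, whose six-membered aromatic ring has 2 hetero atoms, and this read-out does not separate the two groups at this position. No measurement offered here gives a reason for this result.

The compounds shown leave open what a group without an aromatic ring on this nitrogen would do, such as a plain hydrogen, an acetyl group or a carboxylic acid on a short chain, and whether a longer chain carrying the pyridin-4-yl ring would fit the same picture. On these data alone, as this assay gives a percentage at a single concentration and not a potency, it also remains open whether compound 2 and compound 4 would stay inseparable across a range of concentrations.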